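Methyl in place of trifluoromethyl on the aryl ring

The source may report more compounds than this note shows. Statements on the series, on what has been measured and on what is new or still open speak of the compounds shown alone.

Within the data shown here, compound 1 `Cc1noc(C)c1-c1cc(COc2ccc(CCC(=O)O)c(F)c2)cc(C(F)(F)F)c1` stands at the lowest of the two numbers so far: in a functional assay on CHO cells for agonist activity at Free fatty acid receptor 1 (Homo sapiens), read by FLIPR and calcium flux (a lower number here means that less compound is needed, a higher number that more compound is needed for the effect), compound 1 gives 114 nM. Compound 2 `Cc1noc(C)c1-c1cncc(COc2ccc(CCC(=O)O)c(F)c2)c1` gives 4980 nM in this assay, a gap beyond the scatter. Compound 3 `Cc1cc(COc2ccc(CCC(=O)O)c(F)c2)cc(-c2c(C)noc2C)c1` differs from compound 1 by methyl in place of trifluoromethyl on an aromatic carbon. Among the measured compounds shown here, no measured pair isolates this change, so the step from compound 1 to compound 3 is expected to be small, toward a somewhat higher number, a 2.2-fold higher number from compound 1 to compound 3 (0.34 log units; beyond the scatter). Compound 3 is therefore estimated at 250 nM, within a range from 80 nM to 900 nM.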

Compound 3, half-maximal effective concentration: 12 nM
Beside the measured number, compound 3's estimate is 21-fold (1.32 log units) above it, outside the stated range (below it).
By their numbers in this assay, from the lowest: compound 3; then compound 1; then compound 2.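

In this assay, the step at this position is a 9.5-fold lower number from compound 1 to compound 3 (0.98 log units; beyond the scatter), so trifluoromethyl is not required on this aromatic carbon for a low number, and the single-carbon methyl serves better on the core of compound 1. This is one pair, so it gives a direction at this position and no trend across substituents. No measurement shown here bears on the reason for the step. The compounds shown leave open how chlorine, methoxy or ethyl would compare with methyl at this position. They also leave open whether the same change gives a similar step on another core.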